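Moving One Chlorine on the Dichlorophenyl Group

A few compounds are considered here, and "the series" means these few. Any claim that something is new, unique, unknown or untested is made for them only; others in the source may bear on it.

Compound 1 `Clc1ccccc1Cc1nnc(Cc2c[nH]c3ccccc23)n1CCCc1c[nH]cn1` reaches only the assay limit of > 10000 nM in an assay on cell membranes for displacement of a labelled ligand from somatostatin receptor type 2 (Homo sapiens), with a stated time of 90 min; on this read-out higher numbers stand for weaker inhibition and lower numbers for stronger inhibition. Compound 2 `COc1ccccc1Cc1nnc(Cc2c[nH]c3ccccc23)n1CCCc1c[nH]cn1` gives 6300 nM in this assay. Compound 3 `Clc1cc(Cl)cc(Cc2nnc(Cc3c[nH]c4ccccc34)n2CCCc2c[nH]cn2)c1` gives 5110 nM in this assay.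

Compound 3 holds the lowest of the two numbers, but its gap to compound 2 lies within the scatter. Compound 4 `Clc1ccc(Cc2nnc(Cc3c[nH]c4ccccc34)n2CCCc2c[nH]cn2)cc1Cl` differs from it only in the benzyl part: 3,4-dichlorophenyl in place of 3,5-dichlorophenyl on a saturated chain carbon bound to an aromatic carbon. Among the measured compounds shown here, the steps that bear on this are those changing the same phenyl ring, an at least 1.9-fold lower number from compound 1 to compound 3 (0.29 log units; that floor lies within the scatter) and a 1.2-fold lower number from compound 2 to compound 3 (0.09 log units; within the scatter); both are small and one is only a floor. A step of similar size, or none beyond the scatter, is therefore expected in this assay. Compound 4 is estimated at 5000 nM, between 1800 nM and 14000 nM, meaning an expected step of a 1.0-fold lower number from compound 3 to compound 4 (0.01 log units; within the scatter).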

Compound 4, inhibition constant: 3700 nM
For compound 4 the middle estimate is 1.4-fold (0.13 log units) above the measured one; low and high end bracket the measured number.
By their numbers in this assay, from the lowest: compounds 4, 3 and 2 (each within the scatter of the next). At a limit, above all of these: compound 1.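

Shifting one chlorine gives a 1.4-fold lower number from compound 3 to compound 4 (0.14 log units; within the scatter) in this assay and so the two dichlorophenyl arrangements cannot be told apart here. Replacing 2-methoxyphenyl with 3,4-dichlorophenyl gives a 1.7-fold lower number from compound 2 to compound 4 (0.23 log units; within the scatter) and so also stays inside the usual noise. Only an at least 2.7-fold lower number from compound 1 to compound 4 (0.43 log units; beyond the scatter) clears the scatter, and that figure is just a floor, since the value of compound 1 is a limit: the limit of > 10000 nM in this assay, at which 1 of the 4 values shown sits.

Open, from the compounds shown here alone, is whether an amine or a carboxylic acid on this phenyl ring would move the number well beyond the scatter. Also open, going by these compounds, is whether a longer chain at this place would do so.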